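A methyl added to the sulfonamide chain

The source may report more compounds than this note shows. Statements on the series, on what has been measured and on what is new or still open speak of the compounds shown alone.

Of the compounds shown here, three have so far been measured in a functional assay on K562 cells (Homo sapiens) for antiproliferative activity, read by CCK-8 assay, with a stated time of 72 h; a lower number here means a stronger inhibitor of growth, a higher number a weaker inhibitor of growth. Compound 1, `CCCNS(=O)(=O)c1ccc(Nc2ncc3c(n2)N(c2ccn(C)n2)C(CC)C(=O)N3C)cc1`, gives 2260 nM in this assay. Compound 3, `CCCNS(=O)(=O)c1ccc(Nc2ncc3c(n2)N(C2CCCC2)[C@H](CC)C(=O)N3C)cc1`, gives 548 nM, and compound 2, `CCCCNS(=O)(=O)c1ccc(Nc2ncc3c(n2)N(C2CCCC2)[C@H](CC)C(=O)N3C)cc1`, gives 412 nM. Compound 1 therefore shows the highest of the three numbers; its nearest neighbour is compound 3, and the gap between the two lies beyond the scatter, as does the wider gap to compound 2.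

Compounds 3 and 2 differ in a single place: methyl in place of hydrogen on a saturated chain carbon, three bonds along the chain from a sulfonamide nitrogen. In this assay that change makes a step of a 1.3-fold lower number from compound 3 to compound 2 (0.12 log units; within the scatter), which is within the scatter, so the two values cannot be told apart with confidence.

Compound 4, `CCCCNS(=O)(=O)c1ccc(Nc2ncc3c(n2)N(c2ccn(C)n2)C(CC)C(=O)N3C)cc1`, has not yet been measured. It relates to compound 1 exactly as compound 2 relates to compound 3: methyl in place of hydrogen on a saturated chain carbon, three bonds along the chain from a sulfonamide nitrogen. The description of the place is the same word for word in both pairs, so this is the same change, carried out on a different core. How the core of compound 1 differs from the core of compound 3 is not broken down here.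

A step of a 1.3-fold lower number from compound 1 to compound 4 (0.10 log units; within the scatter) in this assay is expected for compound 4, because the same change gave a 1.3-fold lower number from compound 3 to compound 2 (0.12 log units; within the scatter). Compound 4 is therefore estimated at 1800 nM in this assay, most likely between 900 nM and 3600 nM.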

Compound 4, concentration for 50% growth inhibition: 4240 nM
Compound 4: middle estimate off by 2.4-fold (0.37 log units), on the low side; the measured number lies above the stated range.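

In this assay, lengthening the sulfonamide chain from propyl to butyl on the core of compound 1 gives a 1.9-fold higher number from compound 1 to compound 4 (0.27 log units; within the scatter), so the two compounds cannot be told apart with confidence. Set beside the same change on the other core, this step does not differ from the earlier one by more than repeated measurements could explain: the same change on two cores in this assay, a 1.3-fold lower number (0.12 log units; within the scatter) from compound 3 to compound 2 and a 1.9-fold higher number (0.27 log units; within the scatter) from compound 1 to compound 4, 2.5-fold (0.40 log units) apart, within the scatter of two such steps. This shows that, on both cores, the added methyl leaves the number within the usual scatter, and that nothing here separates the way the two cores respond; it does not show that the change has a real effect of either sign on either core, nor that the two cores truly respond alike, and the different directions of the two printed steps should not be read as a finding.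

The compounds shown leave open whether a longer chain such as pentyl, or a chain ending in an amine or a carboxylic acid, would move the number beyond the scatter on either core. Among the compounds shown here, they also cover only two cores, so whether the propyl to butyl change stays this small on any further core remains unknown.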